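Swapping 1,3-oxazol-4-yl for 1H-imidazol-2-yl: an exposure estimate

The compounds below may be only part of what the source reports. "The series", "measured", "known", "first", "only" and "open" are said of these compounds alone.

In an ADME assay on the whole organism (plasma, strain 129/SvEvBrd x C57BL/6) for pharmacokinetics, with Mus musculus as the target, at a dose of 10 mg/kg by the oral route (on this read-out higher numbers stand for higher exposure at the dose given and lower numbers for lower exposure), compound 1 `CC(O)c1nc([C@@H](O)[C@H](O)[C@H](O)CO)c[nH]1` gives 10300 ng.h/mL, compound 2 `CN(C)C(=O)c1nc([C@@H](O)[C@H](O)[C@H](O)CO)c[nH]1` gives 1740 ng.h/mL and compound 3 `OC[C@@H](O)[C@@H](O)[C@H](O)c1c[nH]c(-c2cocn2)n1` gives 868 ng.h/mL. Compound 3 therefore stands well down the short series, as the data show a 12-fold lower number from compound 1 to compound 3 (1.07 log units; beyond the scatter), a large step. The other gap, a 2.0-fold lower number from compound 2 to compound 3 (0.30 log units; within the scatter), does not separate the two compounds.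

Compound 4 `OC[C@@H](O)[C@@H](O)[C@H](O)c1c[nH]c(-c2ncc[nH]2)n1` keeps the shared core and carries 1H-imidazol-2-yl in place of 1,3-oxazol-4-yl on an aromatic carbon, between two ring nitrogen atoms: 1H-imidazol-2-yl in place of 1,3-oxazol-4-yl on an aromatic carbon.

All three measured steps change the group at this same place. Two of them start from 1-hydroxyethyl, which compound 4 lacks: the large step already given and a 5.9-fold lower number from compound 1 to compound 2 (0.77 log units; beyond the scatter), a modest one. They say little about the present change. The closest guide is the step that leaves 1-hydroxyethyl out of the comparison, and it stayed within the scatter. For the measured compounds named here, no measured compound carries 1H-imidazol-2-yl, so the uncertainty is wide. The expected change is a 1.0-fold higher number from compound 3 to compound 4 (0.02 log units; within the scatter), which means no step beyond the scatter in either direction. Compound 4 is estimated at 900 ng.h/mL, with an expected range of 280 ng.h/mL to 2900 ng.h/mL.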

Compound 4, area under the concentration-time curve: 1500 ng.h/mL
Compound 4: the middle estimate sits 1.7-fold (0.22 log units) below what was measured, and the stated range covers the measured number.
By their numbers in this assay, from the lowest: compounds 3, 4 and 2 (each within the scatter of the next); then compound 1.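

In this assay, the exchange of 1,3-oxazol-4-yl for 1H-imidazol-2-yl on an aromatic carbon between two ring nitrogen atoms keeps the heavy atom count and adds a hydrogen-bond donor, yet the result (a 1.7-fold higher number from compound 3 to compound 4 (0.24 log units; within the scatter)) stays within the scatter, so at this position that donor brings no change that can be read. Compound 4 also cannot be separated from the dimethylcarbamoyl compound (a 1.2-fold lower number from compound 2 to compound 4 (0.06 log units; within the scatter)), while the distance from the 1-hydroxyethyl compound (a 6.9-fold lower number from compound 1 to compound 4 (0.84 log units; beyond the scatter)) lies beyond the scatter, so among these four compounds the two aromatic rings and the amide form one group and compound 1 alone stands apart. The data shown offer no measured reason for any of these numbers.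

The compounds shown do not tell whether the higher exposure of compound 1 would survive with a close relative of 1-hydroxyethyl, such as 1-aminoethyl or plain ethyl. They also leave open what a methyl group on the ring nitrogen of 1H-imidazol-2-yl, which would remove the added donor, would do to exposure.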